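Hydrazine series: nitro in place of methoxy

The source may report more compounds than this note shows. Statements on the series, on what has been measured and on what is new or still open speak of the compounds shown alone.

Three measured compounds share one core and differ only at a single aromatic carbon of the aryl hydrazine. In a functional assay on the whole organism for inhibition, with Rattus norvegicus as the target, read by paw edema, with a stated time of 2 h, at a dose of 50 mg/kg (a higher number here means more inhibition at the dose given (going by the name of the read-out), a lower number less inhibition), compound 1 `CC(=O)c1c(NNc2ccccc2)cc(C)oc1=O` gives 57.3%. Compound 2 `CC(=O)c1c(NNc2ccc(Cl)cc2)cc(C)oc1=O` gives 57.3% in this assay, and no change at the digits printed from compound 1 to compound 2 (within the scatter). Compound 3 `COc1ccc(NNc2cc(C)oc(=O)c2C(C)=O)cc1` gives 49.4% in this assay; a number 7.9 percentage points lower from compound 1 to compound 3 (within the scatter) and a number 7.9 percentage points lower from compound 2 to compound 3 (within the scatter). On the numbers shown compound 3 therefore sits apart from compound 1 and compound 2 only by gaps that fall inside the scatter, so no ordering among the three can be read from this assay.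

Compound 4 `CC(=O)c1c(NNc2ccc([N+](=O)[O-])cc2)cc(C)oc1=O` is not yet measured. It differs from compound 3 as follows: nitro in place of methoxy on an aromatic carbon. Among the compounds with values here, the steps that bear on this change are the three aromatic substituent swaps already seen, all of which stayed within the scatter in this assay. The new group enters at the same place, so a step of no more than the scatter is expected in this assay, with no preferred direction. Compound 4 is thus estimated to give 52% in this assay, within a range of 38% to 66%, which means an expected step of a number 2.6 percentage points higher from compound 3 to compound 4 (within the scatter).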

Compound 4, a percentage reported as inhibition, in the whole organism at one dose (the size of the read-out at that dose, not a potency): 55.1%
Compound 4: the middle estimate sits 3.1 percentage points below what was measured; measured number inside the range.
By their numbers in this assay, from the lowest: compounds 3, 4, 1 and 2 (each within the scatter of the next).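

With nitro on the aromatic carbon para to a large group, this assay shows a number 5.7 percentage points higher from compound 3 to compound 4 (within the scatter) and a number 2.2 percentage points lower from compound 2 to compound 4 (within the scatter) and also a number 2.2 percentage points lower from compound 1 to compound 4 (within the scatter) in the same reading. The earlier compounds shown here covered only hydrogen, chloro and methoxy at this carbon; nitro now joins them, and all six pairs among the four compounds stay within the scatter, so no ordering of these groups can be read at this single dose and time. Even the change from methoxy to nitro, in which none of the heavy atoms of the leaving group's pair of carbon and oxygen carries over unchanged as a group, leaves the read-out no more separated than the smaller swaps from hydrogen did.

On these data alone, whether an amine, a carboxylic acid or a longer alkoxy chain at this carbon would move the number beyond the scatter remains open, as does the effect of placing any of these groups on another carbon of the same ring. What lies behind the closeness of these four numbers also stays open, as no data bearing on it are at hand.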